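The compounds below may be only part of what the source reports. "The series", "measured", "known", "first", "only" and "open" are said of these compounds alone.

Compound 1 `CC(C)c1ccc2c(Nc3cc(C(=O)N[C@@H](C)C4CCCCC4)ccc3Sc3ccc(N)cc3)ncnc2n1`: 0.5 h
Compound 2 `CC(C)c1ccc2c(Nc3cc(C(=O)N[C@@H](C)c4ccc(Br)cc4)ccc3Sc3ccc(N)cc3)ncnc2n1`: 1.9 h
Compound 3 `CC(C)c1ccc2c(Nc3cc(C(=O)N[C@@H](C)c4ccccc4)ccc3Sc3ccc(N)cc3)ncnc2n1`: 1.6 h

These three compounds share one core and were tested in an ADME assay on the whole organism (strain Sprague-Dawley) for metabolic stability, with Rattus norvegicus as the target, at a dose of 5 mg/kg by the intravenous route; a higher number here means that the compound lasts longer, a lower number that the compound disappears faster. Compound 3 stands second highest of the three numbers: the step of a 1.2-fold lower number from compound 2 to compound 3 (0.07 log units; within the scatter) lies within the scatter, while the step of a 3.2-fold higher number from compound 1 to compound 3 (0.51 log units; beyond the scatter) lies beyond it. Compound 4 `COC(=O)Nc1ccc(Sc2ccc(C(=O)N[C@@H](C)c3ccccc3)cc2Nc2ncnc3nc(C(C)C)ccc23)cc1` differs from compound 3 in one place: methoxycarbonyl in place of hydrogen on a nitrogen on an aromatic ring. For the measured compounds named here, no measured step touches this part of the molecule. Two steps were modest, a 3.8-fold higher number from compound 1 to compound 2 (0.58 log units; beyond the scatter) and a 3.2-fold higher number from compound 1 to compound 3 (0.51 log units; beyond the scatter), and one lay within the scatter, a 1.2-fold lower number from compound 2 to compound 3 (0.07 log units; within the scatter); all three concern the group on the saturated chain carbon bound to the amide-type nitrogen, and the amino group on the aromatic ring is the same in compound 1, compound 2 and compound 3. There is thus no measured guide for the methoxycarbonyl. The expected step for compound 4 is no change at the digits printed from compound 3 to compound 4 (within the scatter), none beyond the scatter. Compound 4 is estimated at 1.6 h, with a range from 0.7 h to 3.5 h.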

Compound 4, half-life: 0.4 h
The estimate for compound 4 lay 4.0-fold (0.60 log units) above the measured number; the measured number lies below the stated range.
By their numbers in this assay, from the lowest: compounds 4 and 1 (each within the scatter of the next); then compounds 3 and 2 (each within the scatter of the next).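

For the compounds shown here, this is the first step that touches the amino group, since all earlier steps concerned the group on the saturated chain carbon bound to the amide-type nitrogen. In this assay, changing 4-aminophenyl to 4-((methoxycarbonyl)amino)phenyl gives a 4.0-fold lower number from compound 3 to compound 4 (0.60 log units; beyond the scatter), so this nitrogen on an aromatic ring is a position where a change can move the half-life, by a step also rated modest, like a 3.2-fold higher number from compound 1 to compound 3 (0.51 log units; beyond the scatter). Nothing available explains why the number fell.

On these data alone, it remains open whether a smaller group on this nitrogen, such as an acetyl or a methyl, would shift the number in the same way. As far as these compounds go, it is also open whether the methoxycarbonyl would give a similar step with 4-bromophenyl or cyclohexyl in place of the phenyl.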